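An isomeric pyrazolyl sulfonamide awaits its clearance reading

The source may report more compounds than this note shows. Statements on the series, on what has been measured and on what is new or still open speak of the compounds shown alone.

Compound 1 `CCn1c([C@@H](C)NS(=O)(=O)c2ccc(CC(C)C)cc2)nc2ccc(C(F)(F)F)cc21` gives > 100 mL.min-1.g-1 (a limit)
Compound 2 `CCn1c([C@@H](C)NS(=O)(=O)c2ccccn2)nc2ccc(C(F)(F)F)cc21` gives < 3 mL.min-1.g-1 (a limit)
Compound 3 `CCCn1cc(S(=O)(=O)N[C@H](C)c2nc3ccc(C(F)(F)F)cc3n2CC)c(C)n1` gives > 100 mL.min-1.g-1 (a limit)

All three readings are limits of the assay and not numbers. In an ADME assay (liver) for metabolic stability, with Liver microsome (Homo sapiens) as the target, read by LC-MS, using microsomes and NADPH, with a stated time of 5 min, at 37 degrees C (on this read-out higher numbers stand for fast clearance and lower numbers for slow clearance), compound 3 gives > 100 mL.min-1.g-1 as its reading, and this too is only a limit. It therefore stands at the limit of > 100 mL.min-1.g-1 in this assay, at which 2 of the 3 values shown sit, and has no exact position there.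

Compound 4 `CCn1c([C@@H](C)NS(=O)(=O)c2cnn(C(C)C)c2C)nc2ccc(C(F)(F)F)cc21` has the same atoms as compound 3, joined differently. The change is a group of 9 heavy atoms (7 carbon, 2 nitrogen; one five-membered aromatic ring with 2 hetero atoms) in place of a group of 9 heavy atoms (7 carbon, 2 nitrogen; one five-membered aromatic ring with 2 hetero atoms), on a sulfonyl sulfur, and the entering group is 1-isopropyl-5-methyl-1H-pyrazol-4-yl.

The measured steps all concern this same place. There is an at least 33-fold lower number from compound 1 to compound 2 (1.52 log units; beyond the scatter), and there is an at least 33-fold higher number from compound 2 to compound 3 (1.52 log units; beyond the scatter). Both are large, so in these compounds the group on the sulfonyl sulfur has mattered greatly. The third, a step that the two limits leave unreadable from compound 1 to compound 3, adds no size. None of these steps exchanges one group for another of the same counted makeup, so they give no direct measure for this change. Compound 4 is therefore expected to stay close to compound 3, with no step beyond the scatter. The expected step is an at least 1.2-fold lower number from compound 3 to compound 4 (0.09 log units; that floor lies within the scatter), and it remains uncertain since it starts from a limit. Compound 4 is estimated at 80 mL.min-1.g-1, with an expected range from 30 mL.min-1.g-1 to 150 mL.min-1.g-1, and it may well return only a limit.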

Compound 4, intrinsic clearance in microsomes: > 100 mL.min-1.g-1
Compound 4: only a limit was reported; the forecaster's own chance of this, stated with the estimate: 45%; middle value at least 1.2-fold (0.09 log units) away from the limit.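

In this assay compound 4 gives > 100 mL.min-1.g-1, which is a limit of the assay and not a number. Joining the same atoms differently, as 1-isopropyl-5-methyl-1H-pyrazol-4-yl on the sulfonyl sulfur, therefore does not bring the reading off that limit, and the steps from compound 1 and from compound 3 to compound 4 cannot be read, so compound 4 simply joins those two compounds: the limit of > 100 mL.min-1.g-1 in this assay, at which 3 of the 4 values shown sit. Against pyridin-2-yl, the second pyrazolyl group gives an at least 33-fold higher number from compound 2 to compound 4 (1.52 log units; beyond the scatter), so the large gap first seen with compound 3 is not confined to one arrangement of these atoms, and compound 2 remains the only one of the compounds shown that goes against the high readings: the limit of < 3 mL.min-1.g-1 in this assay, at which 1 of the 4 values shown sits.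

On these data alone, whether compound 3 and compound 4 differ at all, and by how much, stays open, since both readings are limits. Also open, as far as these compounds go, is whether a pyrazolyl group carrying a carboxylic acid or an amine, or a pyridin-2-yl group carrying an isobutyl chain, would give a reading that lies inside the range of the assay.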